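Removing the Methyl From the Ether Oxygen of Compound 1

A few compounds are considered here, and "the series" means these few. Any claim that something is new, unique, unknown or untested is made for them only; others in the source may bear on it.

Compound 1 `COc1cc(-c2nn(-c3ccc(NC(=O)Nc4ccc(Cl)c(C(F)(F)F)c4)cc3)cc2-c2ccncc2)ccc1Cl` was tested in a functional assay on SK-MEL-28 cells (Homo sapiens) for antiproliferative activity, read by sulforhodamine B assay, with a stated time of 48 h (a lower number here means a stronger inhibitor, a higher number a weaker inhibitor), where compound 1 gives 1880 nM. Compound 3 `COc1cc(-c2nn(-c3ccc(NC(=O)c4ccc(Cl)c(C(F)(F)F)c4)cc3)cc2-c2ccncc2)ccc1Cl` gives 2800 nM in this assay, and the step of a 1.5-fold higher number from compound 1 to compound 3 (0.17 log units; within the scatter) is within the scatter, so the two are not set apart from each other. Compound 2 `COc1cc(-c2nn(-c3ccc(NC(=O)c4cc(Cl)cc(Cl)c4)cc3)cc2-c2ccncc2)ccc1Cl` gives only a limit in this assay, > 100000 nM; this is the limit of > 100000 nM in this assay, at which 1 of the 3 values shown sits. The steps of an at least 53-fold higher number from compound 1 to compound 2 (1.72 log units; beyond the scatter) and an at least 35-fold lower number from compound 2 to compound 3 (1.55 log units; beyond the scatter) are both large, and all three measured steps alter what sits on the carbonyl carbon.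

Compound 4 `O=C(Nc1ccc(-n2cc(-c3ccncc3)c(-c3ccc(Cl)c(O)c3)n2)cc1)Nc1ccc(Cl)c(C(F)(F)F)c1` differs from compound 1 elsewhere: hydrogen in place of methyl on an oxygen on an aromatic ring. For the measured compounds named here, none of the measured steps touches this part of the shared core; each of them leaves the 4-chloro-3-methoxyphenyl group unchanged and concerns only the urea or amide side. Going by the values given here, the measured steps therefore give no direct precedent for this change, and the account expects no step beyond the scatter. The step it expects is a 1.3-fold higher number from compound 1 to compound 4 (0.12 log units; within the scatter). For compound 4 the estimated value in this assay is 2500 nM, expected to lie between 800 nM and 8000 nM.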

Compound 4, half-maximal inhibitory concentration: 1630 nM
For compound 4 the middle estimate is 1.5-fold (0.19 log units) above the measured one, and the stated range covers the measured number.
By their numbers in this assay, from the lowest: compounds 4, 1 and 3 (each within the scatter of the next). At a limit, above all of these: compound 2.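

For the compounds shown here, until compound 4, every measured step had concerned the urea or amide side and left the 4-chloro-3-methoxyphenyl group as it was, so this is the first reading at this position. In this assay the exchange of methoxy for hydroxy gives a 1.2-fold lower number from compound 1 to compound 4 (0.06 log units; within the scatter) and so does not set the two compounds apart, which means that for this pair the methyl on the oxygen can give way to hydrogen, one heavy atom fewer, without a difference that the measurement can resolve. This is a single pair on a single urea background, and nothing given here accounts for the outcome.

On these data alone, what an amine or a longer chain such as ethoxy in place of the methoxy group would give in this assay remains open, as does the result of a carboxylic acid at this position. As far as these compounds go, it also remains open whether 4-chloro-3-hydroxyphenyl would read the same on the amide background of compound 3 as it does on the urea background of compound 1.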